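Piperazin-1-yl in place of 4-aminophenyl on the shared core

The source may report more compounds than this note shows. Statements on the series, on what has been measured and on what is new or still open speak of the compounds shown alone.

In a functional assay on MDA-MB-231 cells (Homo sapiens) for inhibition, read by MTT assay, with a stated time of 72 h (on this read-out lower numbers stand for stronger inhibition and higher numbers for weaker inhibition), compound 1 (`CC(C)(C)n1cc2c(n1)C(=O)CC1(CCN(C(=O)c3cc(-c4ccc(Br)cc4)nc4ccccc34)CC1)O2`) gives > 10000 nM as its reading, which is a limit of the assay and not a number. Among the measured compounds shown here, compound 2 (`CC(C)(C)n1cc2c(n1)C(=O)CC1(CCN(C(=O)c3cc(-c4ccc(N)cc4)nc4ccccc34)CC1)O2`) gives 4960 nM as the only actual number so far. Compound 3 (`CC(C)(C)n1cc2c(n1)C(=O)CC1(CCN(C(=O)c3cc(N4CCNCC4)nc4ccccc34)CC1)O2`) carries piperazin-1-yl in place of 4-aminophenyl on an aromatic carbon, next to the ring nitrogen. For the measured compounds named here, the one measured step, amino in place of bromo on an aromatic carbon (an at least 2.0-fold lower number from compound 1 to compound 2 (0.30 log units; that floor lies within the scatter)), has only a floor for its size. It was also measured on the very group that now leaves, so it is a weak guide. No step beyond the scatter is therefore expected in this assay in either direction. The estimate means a 1.0-fold higher number from compound 2 to compound 3 (0.00 log units; within the scatter) as the expected step. The estimated value for compound 3 is 5000 nM with a range of 1500 nM to 12000 nM as the likely span.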

Compound 3, half-maximal inhibitory concentration: 4200 nM
Beside the measured number, compound 3's estimate is 1.2-fold (0.08 log units) above it; measured number inside the range.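

In this assay, piperazin-1-yl in place of 4-aminophenyl gives a 1.2-fold lower number from compound 2 to compound 3 (0.07 log units; within the scatter), so at this position a six-membered non-aromatic ring with 2 hetero atoms reads like the six-membered aromatic ring of carbon only that it replaces. Piperazin-1-yl in place of 4-bromophenyl gives an at least 2.3-fold lower number from compound 1 to compound 3 (0.37 log units; beyond the scatter), the first step at this position that lies beyond the scatter. Its true size cannot be read, because compound 1 rests on a limit of the assay and not on a number: the limit of > 10000 nM in this assay, at which 1 of the 3 values shown sits.

Going by these compounds, it remains open whether morpholin-4-yl or 4-methylpiperazin-1-yl at this position would read any differently from piperazin-1-yl. The compounds shown also leave open whether any group here, such as a carboxylic acid on the phenyl ring, could bring the reading far under those of compound 2 and compound 3.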